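Swapping Ethoxycarbonyl for Acetamido in Compound 3

The source may hold more compounds than are shown below. What is called first, only, known or untested is meant among the compounds shown, and "the series" means these compounds.

Compound 2 `CCOC(=O)c1ccc(NC(=S)Nc2ccc3[nH]ccc3c2)cc1` gives 65.8% in an ADME assay on isolated protein for inhibition of peroxidase (Raphanus sativus), read by fluorescence and Amplex Red, tested at 5 uM (on this read-out lower numbers stand for a stronger effect and higher numbers for a weaker effect at the one concentration tested), the lowest of the two numbers measured, although its gap to compound 1 `CC(=O)c1ccc(NC(=S)Nc2ccc3[nH]ccc3c2)cc1` lies within the scatter, compound 1 giving 66.3%. Compound 3 `CC(=O)Nc1ccc(NC(=S)Nc2ccc3[nH]ccc3c2)cc1` differs from compound 2 by acetamido in place of ethoxycarbonyl on an aromatic carbon. Among the measured compounds shown here, the only measured step, a number 0.5 percentage points lower from compound 1 to compound 2 (within the scatter), also reworked this group and stayed within the scatter, so it bears only loosely on the present exchange. No step beyond the scatter is therefore expected in this assay, the expected change being a number 0.2 percentage points higher from compound 2 to compound 3 (within the scatter). Compound 3 is estimated at 66%, between 50% and 82%.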

Compound 3, a percentage reported as activity, at one concentration (the size of the read-out at that concentration, not a potency): 68.1%
Compound 3: middle estimate off by 2.1 percentage points, on the low side; low and high end bracket the measured number.
By their numbers in this assay, from the lowest: compounds 2, 1 and 3 (each within the scatter of the next).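

In this assay, acetamido, which carries a hydrogen-bond donor, in place of ethoxycarbonyl, which carries none, on an aromatic carbon para to a large group gives a number 2.3 percentage points higher from compound 2 to compound 3 (within the scatter). Acetamido in place of acetyl gives a number 1.8 percentage points higher from compound 1 to compound 3 (within the scatter), so the nitrogen-linked group and both carbonyl-linked groups all sit within the scatter of one another at this position. No independent measurement is available to explain this result.

On these data alone, whether an amine or a carboxylic acid at this position would also stay within the scatter remains open. So does whether this insensitivity would hold for a longer chain.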